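Swapping the Ring on the Amide Nitrogen

This account rests on a few compounds, and the source may have more. Where it says the series, first, only, none or still open, it means among the compounds named here.

Of the compounds shown here, two have been tested in an assay on cells for agonist activity at D(4) dopamine receptor (Homo sapiens), read by luminescence and beta-arrestin recruitment, with a stated time of 90 min; on this read-out lower numbers stand for an effect already at smaller amounts and higher numbers for an effect only at larger amounts of compound. Compound 1 `Cc1cccc(NC(=O)CN2CCC(c3ccc(Cl)cc3)CC2)c1` gives "not active" (no number reported) in this assay, and no number accompanies that result. For the measured compounds named here, compound 2 `O=C(CN1CCN(c2ccccn2)CC1)Nc1cccnc1` gives 2660 nM in this assay, which makes it the only compound with a numerical result in this set; since compound 1 offers no value to compare against, no step between measured compounds can be drawn.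

Compound 3 `O=C(CN1CCN(c2ccccn2)CC1)Nc1cncnc1` differs from compound 2 in one place: pyrimidin-5-yl in place of pyridin-3-yl on an amide-type nitrogen. The amide-type nitrogen, whose other neighbour is the carbonyl carbon, stays as it is; only the aromatic ring attached to it changes, from a six-membered ring with one hetero atom to one with two hetero atoms.

With no comparable exchange measured here, the expected step from compound 2 to compound 3 in this assay is small, a 1.3-fold higher number from compound 2 to compound 3 (0.12 log units; within the scatter), within the scatter or at most slightly toward needing a larger amount of compound. Compound 3 is therefore estimated at 3500 nM in this assay, with a range from 1200 nM to 12000 nM.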

Compound 3, half-maximal effective concentration: "not active" (no number reported)
Compound 3: no number reported; there is nothing to compare the estimate with.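

In this assay, for the compounds shown here, compound 3 gives "not active" (no number reported) and compound 2 gives 2660 nM, so no step between the two can be read. Nothing shown here bears on this result. The compounds shown leave open how large an effect pyrimidin-5-yl in place of pyridin-3-yl on the amide-type nitrogen has on the read-out.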